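This account rests on a few compounds, and the source may have more. Where it says the series, first, only, none or still open, it means among the compounds named here.

Measured in an assay for inhibition of Indoleamine 2,3-dioxygenase 1 (Homo sapiens), with stated times of 10 min and 60 min, tested at 100 uM; a higher number here means a stronger effect of the compound at the concentration tested, a lower number a weaker effect:
compound 1 `Oc1ccc(CNc2cc(C(F)(F)F)cc3[nH]ncc23)cc1` — 81%
compound 2 `O=[N+]([O-])c1ccccc1CNc1cc(Br)cc2[nH]ncc12` — 83%
compound 3 `Oc1ccc(CNc2cc(C(F)(F)F)cc3[nH]ncc23)c(Cl)c1` — 95%

Compound 1 gives the lowest of the three numbers shown, though compound 2 lies within the scatter of it; only compound 3 stands clear, through the step of a number 14 percentage points higher from compound 1 to compound 3 (beyond the scatter). Compound 4 `FC(F)(F)c1cc(NCc2cccc(Br)c2)c2cn[nH]c2c1` differs from compound 1 as follows: 3-bromophenyl in place of 4-hydroxyphenyl on a saturated chain carbon bound to a nitrogen on an aromatic ring. For the measured compounds named here, no measured step covers this change. Going by the values given here, the one measured step is chloro in place of hydrogen on an aromatic carbon, a different change, and compound 2 differs from compound 1 in more than one place, so it gives no isolated reading. All three numbers sit in a narrow band near the top of the scale in this assay, so the expected step of a number 3 percentage points lower from compound 1 to compound 4 (within the scatter) is not beyond the scatter. Compound 4 is estimated at 78%, between 55% and 95%.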

Compound 4, a percentage reported as inhibition, at one concentration (the size of the read-out at that concentration, not a potency): 51%
For compound 4 the middle estimate is 27 percentage points above the measured one; the measured number lies below the stated range.
By their numbers in this assay, from the lowest: compound 4; then compounds 1 and 2 (each within the scatter of the next); then compound 3.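

The substituted phenyl on this chain carbon matters: 3-bromophenyl in place of 4-hydroxyphenyl on a saturated chain carbon bound to a nitrogen on an aromatic ring brings a number 30 percentage points lower from compound 1 to compound 4 (beyond the scatter), the first downward step shown in the series. The entering group differs from the leaving one in both its substituent and its numbered ring position, so this single step cannot separate the two changes. No available evidence bears on the reason for the drop.

Still open, going by these compounds, is how 3-hydroxyphenyl or 4-bromophenyl would read at this position. Also open, on these data alone, is how an amine or a carboxylic acid on this phenyl ring would read.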